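A few compounds are considered here, and "the series" means these few. Any claim that something is new, unique, unknown or untested is made for them only; others in the source may bear on it.

Measured compounds:
compound 1 `Nc1nc(O)c2c(n1)n(C1OC(CO)[C@@H](O)[C@H]1O)c(=O)n2C/C=C/c1ccccc1`, 73%
compound 2 `C=CCn1c(=O)n([C@@H]2O[C@H](CO)[C@H]3OC(C)(CCC(=O)NC)O[C@H]32)c2nc(N)nc(O)c21`, 9%
compound 3 `C=CCn1c(=O)n(CCC(CCOCc2ccccc2)CCOCc2ccccc2)c2nc(N)nc(O)c21`, 68%

In a functional assay on the whole organism (B cells) with Mus musculus as the target (a lower number here means a smaller maximal response, a higher number a larger maximal response), compound 1 gives 73%, the highest of the three numbers. Compound 3 sits nearest to it, within the scatter, so the two cannot be ordered. Compound 2 lies far beneath both, beyond the scatter.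

Compound 4 `COc1ccc(Cn2c(=O)n(C3OC(CO)[C@@H](O)[C@H]3O)c3nc(N)nc(O)c32)cc1` is not yet measured in this assay. Against compound 1 it differs in one place: 4-methoxyphenyl in place of 2-phenylethenyl on a saturated chain carbon bound to an aromatic nitrogen. Within the data shown here, no pair of measured compounds shows this change, and the two values of compound 1 and compound 3, both with a ring-bearing chain on the aromatic nitrogen, differ by less than the scatter; the low value of compound 2 goes with a different sugar part as well as a different chain, so it does not isolate the chain. The step is expected to be small, in the downward direction at most, and quite possibly not beyond the scatter. The expected value for compound 4 in this assay is 58%, range 25% to 85%, which means an expected step of a number 15 percentage points lower from compound 1 to compound 4 (beyond the scatter).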

Compound 4, largest response reached (reported as maximal response), in percent of the reference or control that the assay uses: 44%
Compound 4: the middle estimate sits 14 percentage points above what was measured; measured number inside the range.
By their numbers in this assay, from the lowest: compound 2; then compound 4; then compounds 3 and 1 (each within the scatter of the next).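

In this assay, 4-methoxyphenyl in place of 2-phenylethenyl on a saturated chain carbon bound to an aromatic nitrogen gives a number 29 percentage points lower from compound 1 to compound 4 (beyond the scatter). Among these compounds, this is the first single-place step, and it shows that the maximal response depends on the group at this place, even though both groups hold one six-membered aromatic ring of carbon only and the same count of heavy atoms. The change removes a double bond outside aromatic rings and adds a hydrogen-bond acceptor, but no measurement bears on why the response falls.

With one pair, the loss of the double bond and the arrival of the methoxy group cannot be separated; 3-phenylpropyl or 4-aminobenzyl at this place would be needed to tell them apart. From the compounds shown here alone, whether the same step holds with the other sugar and chain parts of the series also remains open.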